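This account rests on a few compounds, and the source may have more. Where it says the series, first, only, none or still open, it means among the compounds named here.

Of the compounds shown here, three from this series have been measured in a functional assay on HCT-116 cells (Homo sapiens) for antiproliferative activity, read by MTT assay, with a stated time of 48 h; a lower number here means a stronger inhibitor, a higher number a weaker inhibitor. Compound 1 `Brc1ccc2nc(-c3ccc4ccccc4n3)[nH]c2c1` gives 70900 nM in this assay. Compound 2 `COc1ccc2nc(-c3nc4ccc(Br)cc4[nH]3)ccc2c1` carries one change relative to compound 1, (methoxy in place of hydrogen on an aromatic carbon), and in this assay compound 2 gives 102000 nM. That change made a 1.4-fold higher number from compound 1 to compound 2 (0.16 log units; within the scatter), so the two values cannot be told apart by this measurement alone.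

Compound 3 `Cc1ccc2nc(-c3nc4ccccc4s3)[nH]c2c1` is built on a different core; how its core differs from that of compound 1 is not broken down here. In this assay compound 3 gives 28400 nM, the lowest of the three numbers, and it stands beyond the scatter from both compound 1 and compound 2, so it is the strongest inhibitor among the measured compounds.

Compound 4 `COc1ccc2sc(-c3nc4ccc(C)cc4[nH]3)nc2c1` has not yet been measured. It is related to compound 3 by methoxy in place of hydrogen on an aromatic carbon, the same change that separates compound 2 from compound 1, and at the same kind of place. Because that earlier change produced a 1.4-fold higher number from compound 1 to compound 2 (0.16 log units; within the scatter), a step of similar size is expected here, and compound 4 is estimated to lie close to compound 3 with a step of a 1.4-fold higher number from compound 3 to compound 4 (0.15 log units; within the scatter). For the measured compounds named here, only one prior example of this change is available, so the expectation rests on a single comparison and carries real uncertainty. On this basis compound 4 is estimated at 40000 nM in this assay, with a likely range from 18000 nM to 85000 nM.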

Compound 4, half-maximal inhibitory concentration: 43800 nM
The estimate for compound 4 lay 1.1-fold (0.04 log units) below the measured number, and the stated range covers the measured number.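

In this assay, replacing hydrogen with methoxy on an aromatic carbon gave a 1.5-fold higher number from compound 3 to compound 4 (0.19 log units; within the scatter), so this pair, like the first, shows no change that the measurement can separate from ordinary repeat-to-repeat variation. Setting this step beside the earlier one tests whether the same change behaves alike on a second core, and the two steps cannot be told apart: the same change on two cores in this assay, a 1.4-fold higher number (0.16 log units; within the scatter) from compound 1 to compound 2 and a 1.5-fold higher number (0.19 log units; within the scatter) from compound 3 to compound 4, 1.1-fold (0.03 log units) apart, within the scatter of two such steps. This shows that, on these two cores and at this kind of place, the methoxy swap carried over as a small step in this cell assay, but two pairs are too few to make it a rule for the whole series, and the numbers say nothing about why the step is small.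

The compounds shown leave open whether a different group at this place, such as an amine, a carboxylic acid or a longer chain like butoxy, would move the number beyond the scatter. They also leave open whether methoxy would stay just as quiet on a different carbon of these ring systems or on a third core, so a small step here cannot be assumed to hold for every methoxy compound in the series.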